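This account rests on a few compounds, and the source may have more. Where it says the series, first, only, none or still open, it means among the compounds named here.

Working notes on the acylguanidine series. Of the compounds shown here, three carry a measured number so far. Compound 1 `CS(=O)(=O)c1cc(C(=O)N=C(N)N)c(F)cc1F` gives, in a functional assay for inhibition of sodium/hydrogen exchanger (Oryctolagus cuniculus) (on this read-out higher numbers stand for weaker inhibition and lower numbers for stronger inhibition), a value of 630 nM. Compound 2 `Cc1c(C(=O)N=C(N)N)ccc(Cl)c1S(C)(=O)=O` gives 1300 nM in this assay. Compound 3 `CCCc1cc(C)c(C(=O)N=C(N)N)cc1S(C)(=O)=O` gives 5.7 nM in this assay, the lowest number of the three; its gaps to compound 1 and to compound 2 both lie beyond the scatter of repeated measurements, so compound 3 stands as the most potent inhibitor among those measured. Among the measured compounds shown here, no pair of these three differs in only one place, so no single step can be read off within the measured set.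

Compound 4 `Cc1cc(OCc2ccccc2)c(S(C)(=O)=O)cc1C(=O)N=C(N)N` has not yet been measured. Relative to compound 3 it shows (benzyloxy in place of propyl on an aromatic carbon). The entering group is larger and brings a hydrogen-bond acceptor where the propyl chain had none; the rest of the shared core is unchanged.

For the measured compounds named here, nothing among the measured compounds tests a change of this kind at this position, so the expectation rests on compound 3 alone. A modest step toward weaker inhibition in this assay is expected, of the order a 3.5-fold higher number from compound 3 to compound 4 (0.55 log units; beyond the scatter), though a result within the scatter of compound 3 remains possible. Compound 4 is estimated at 20 nM, with a range from 4 nM to 120 nM.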

Compound 4, half-maximal inhibitory concentration: 28 nM
Compound 4: the middle estimate sits 1.4-fold (0.15 log units) below what was measured; low and high end bracket the measured number.
By their numbers in this assay, from the lowest: compound 3; then compound 4; then compound 1; then compound 2.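

On the aromatic carbon ortho to the methylsulfonyl group, meta to the methyl group and para to the group of 6 heavy atoms, the series now has its first read on a change of substituent: in this assay, benzyloxy in place of propyl gives a 4.9-fold higher number from compound 3 to compound 4 (0.69 log units; beyond the scatter). The position therefore carries a group of 8 heavy atoms, with a six-membered aromatic ring and a hydrogen-bond acceptor, at the cost of only a modest step, and compound 4 still gives 28 nM in the nanomolar range. No measured evidence bears on the reason for this step.

This single step does not separate the contribution of the ether oxygen from that of the aromatic ring or of the added size, and a methoxy group, a phenyl group attached directly to the aromatic carbon, or a benzyl group with a carbon in place of the oxygen would be needed to pull these apart. On these data alone, how an amine or a longer chain such as pentyl would fare at this position, and whether the same exchange gives a similar step on a core with different neighbouring groups, also remains open.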